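A few compounds are considered here, and "the series" means these few. Any claim that something is new, unique, unknown or untested is made for them only; others in the source may bear on it.

Among the measured compounds shown here, in an ADME assay on L6 cells (Rattus norvegicus) for cytotoxicity (a higher number here means a weaker inhibitor, a lower number a stronger inhibitor), compound 1 `O=C(Nc1c(O)cccc1-c1nc2c(C(=O)O)cccc2o1)c1cccnc1` gives 240000 nM, the higher of the two numbers measured so far. For the measured compounds named here, the only other measured compound, compound 2 `O=C(Nc1c(O)cccc1-c1nc2c(C(=O)O)cccc2o1)c1cc(-c2ccccc2)nc2ccccc12`, gives 108000 nM, a lower number by a margin just beyond the usual scatter of repeat measurements. Compound 3 `O=C(Nc1c(O)cccc1-c1nc2c(C(=O)O)cccc2o1)c1cc(-c2ccccc2)on1` has not yet been measured. It keeps the core of compound 1 and changes one group, placing 5-phenyl-1,2-oxazol-3-yl in place of pyridin-3-yl on a carbonyl carbon. Going by the values given here, no measured pair shows this exact change, so the expectation is rough. Among the compounds with values here, the only guide is compound 2 at 108000 nM, which suggests a small move towards a lower number in this assay, possibly no larger than the scatter. The expected change is a 1.8-fold lower number from compound 1 to compound 3 (0.27 log units; within the scatter). For compound 3 the estimated value is 130000 nM, within a range of 55000 nM to 280000 nM.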

Compound 3, half-maximal inhibitory concentration: 141000 nM
For compound 3 the middle estimate is 1.1-fold (0.04 log units) below the measured one; the range from low to high includes it.
By their numbers in this assay, from the lowest: compounds 2, 3 and 1 (each within the scatter of the next, the first and the last beyond it).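

Placing 5-phenyl-1,2-oxazol-3-yl in place of pyridin-3-yl on a carbonyl carbon gives a 1.7-fold lower number from compound 1 to compound 3 (0.23 log units; within the scatter) in this assay. Among the compounds shown here, this is the first direct reading of this change, and it shows that a larger group carrying one more aromatic ring can stand at this position without a shift that can be told apart from repeat-measurement noise. Nothing measured on these compounds speaks to the reason for this result.

From the compounds shown here alone, it remains open whether a different kind of group at this place, such as a longer alkyl chain or a carboxylic acid, would move the number beyond the scatter. Going by these compounds, the phenyl and the five-membered ring enter together here, so their separate contributions also remain open.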